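This account rests on a few compounds, and the source may have more. Where it says the series, first, only, none or still open, it means among the compounds named here.

Measured in a functional assay on MDA-MB-231 cells (Homo sapiens) for inhibition, read by MTT assay, with a stated time of 72 h; a lower number here means a stronger inhibitor, a higher number a weaker inhibitor:
Compound 1 `CC(C)(C)OC[C@@H](NC(=O)c1cc(Cl)ccc1OCCNC(=O)OC(C)(C)C)C(=O)Nc1ccc([N+](=O)[O-])cc1Cl`: > 10000 nM
Compound 2 `CC(C)[C@H](NC(=O)c1cc(Cl)ccc1OCCNC(=O)OC(C)(C)C)C(=O)Nc1ccc(C(F)(F)F)cc1Cl`: > 10000 nM
Compound 3 `CC(C)[C@H](NC(=O)c1cc(Cl)ccc1OCCN)C(=O)Nc1ccc(C(F)(F)F)cc1Cl`: 5440 nM

Compound 2 gives > 10000 nM, which is a limit of the assay and not a number. It stands at the limit of > 10000 nM in this assay, at which 2 of the 3 values shown sit.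

Compound 4 `CC(C)[C@H](NC(=O)c1cc(Cl)ccc1OCCNC(=O)OC(C)(C)C)C(=O)Nc1cc(F)cc(C(F)(F)F)c1` differs from compound 2 by 3-fluoro-5-(trifluoromethyl)phenyl in place of 2-chloro-4-(trifluoromethyl)phenyl on an amide-type nitrogen. Within the data shown here, the only measured step is an at least 1.8-fold lower number from compound 2 to compound 3 (0.26 log units; that floor lies within the scatter). It puts hydrogen in place of tert-butoxycarbonyl on an amine nitrogen, a different place, and compound 4 keeps that tert-butoxycarbonyl group. Among the measured compounds shown here, no measured step changes the group on the amide-type nitrogen, so no step beyond the scatter is expected. The expected step is a step that the limit leaves unreadable from compound 2 to compound 4. For compound 4 the estimated value is 12000 nM, with an expected range from 5000 nM to 30000 nM.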

Compound 4, half-maximal inhibitory concentration: 7870 nM
Compound 4: middle estimate off by 1.5-fold (0.18 log units), on the high side, within the range that was stated.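

Compound 4 keeps the tert-butoxycarbonyl group and still gives a value that is a number in this assay, 7870 nM, so a change on the amide-type nitrogen alone is enough to reach a readable value. This first measured change at this position reads as an at least 1.2-fold lower number from compound 2 to compound 4 (0.10 log units; that floor lies within the scatter). Compound 2 gives > 10000 nM, which is a limit, and the full size of the step cannot be read: the limit of > 10000 nM in this assay, at which 2 of the 4 values shown sit.

The compounds shown leave open how compound 4 would read with hydrogen in place of tert-butoxycarbonyl on the amine nitrogen. They also leave open how a phenyl carrying a nitrile or a carboxylic acid in place of trifluoromethyl would read.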